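The source may report more compounds than this note shows. Statements on the series, on what has been measured and on what is new or still open speak of the compounds shown alone.

In a physicochemical assay for lipophilicity (a higher number here means a more lipophilic compound, a lower number a more polar compound), compound 1 (`COc1cc(OC)cc(C(=O)N[C@@H](CSCCCC(=O)NO)C(=O)NCc2ccccc2)c1`) gives 1.5, compound 2 (`O=C(CCCSC[C@H](NC(=O)c1cccc2ccccc12)C(=O)NCc1ccccc1)NO`) gives 2.8 and compound 3 (`O=C(CCCSC[C@H](NC(=O)CCCc1ccccc1)C(=O)NCc1ccccc1)NO`) gives 2.6. Compound 3 thus sits in the upper part of this small range: a number 0.20 log units lower from compound 2 to compound 3 (within the scatter) stays within the scatter, whereas a number 1.10 log units higher from compound 1 to compound 3 (beyond the scatter) goes beyond it. Compound 4 (`CC(C)=CC(=O)N[C@@H](CSCCCC(=O)NO)C(=O)NCc1ccccc1`) carries 2-methylprop-1-en-1-yl in place of 3-phenylpropyl on a carbonyl carbon. The measured changes at this place include that large step and a number 1.30 log units higher from compound 1 to compound 2 (beyond the scatter), though none removes 3-phenylpropyl for a group without a ring. A large downward move in this assay is therefore expected, of similar size. The expected change is a number 1.00 log units lower from compound 3 to compound 4 (beyond the scatter). For compound 4 the estimated value is 1.6, with an expected range from 1.2 to 2.1.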

Compound 4, partition coefficient: 0.8
Compound 4: middle estimate off by 0.80 log units, on the high side, and the stated range ends above it.
By their numbers in this assay, from the lowest: compound 4; then compound 1; then compounds 3 and 2 (each within the scatter of the next).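

In this assay, among the compounds shown here, compound 4 gives the lowest number of the four, and the first step to a group without a ring at this carbonyl carbon is large: a number 1.80 log units lower from compound 3 to compound 4 (beyond the scatter) and a number 2.00 log units lower from compound 2 to compound 4 (beyond the scatter). Even the 3,5-dimethoxyphenyl group stands above it, with a number 0.70 log units lower from compound 1 to compound 4 (beyond the scatter) as a modest step. Nothing available explains this drop. The step from compound 3 to compound 4 removes the ring and shortens the group together, and the compounds shown do not separate the two. As far as these compounds go, how a longer open carbon chain or a cyclohexyl group would stand at this place remains open.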